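This account rests on a few compounds, and the source may have more. Where it says the series, first, only, none or still open, it means among the compounds named here.

Compounds measured so far:

Compound 1, `CC(C)[C@H]1CC[C@@]2(CO2)[C@H]2C(=O)OCC(C(=O)OCc3ccc(-c4ccc([N+](=O)[O-])cc4)o3)=C[C@H]12`: 450 nM
Compound 2, `CC(C)[C@H]1CC[C@@](O)(CI)[C@H]2C(=O)OCC(C(=O)O)=C[C@H]12`: 5430 nM
Compound 3, `COC(=O)C1=C[C@@H]2[C@@H](C(C)C)CC[C@@]3(CO3)[C@H]2C(=O)OC1`: 450 nM

The three compounds were compared in a functional assay on A549 cells (Homo sapiens) for inhibition, with a stated time of 72 h; on this read-out lower numbers stand for stronger inhibition and higher numbers for weaker inhibition. Compound 3 stands level with compound 1 at the digits shown; the two give together the lowest numbers of the three. The gap from compound 3 to compound 2 is the largest in the set, compound 2 giving a number beyond the scatter above the other two. Within the data shown here, no single-change pair among the measured compounds is available, so the effect of an isolated change has not yet been observed.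

Compound 4, `CNC(=O)C1=C[C@@H]2[C@@H](C(C)C)CC[C@@]3(CO3)[C@H]2C(=O)OC1`, has not been measured. It differs from compound 3 in one place: methylamino in place of methoxy on a carbonyl carbon. Among the measured compounds shown here, no pair in the data shows this difference, so its effect can only be guessed. Compound 4 is expected to give a somewhat higher number than compound 3, with the step of a 2.0-fold higher number from compound 3 to compound 4 (0.30 log units; within the scatter) estimated to lie close to the edge of the scatter. In this assay compound 4 is estimated at 900 nM, with a range from 300 nM to 3000 nM.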

Compound 4, half-maximal inhibitory concentration: 5540 nM
Estimate against measurement, compound 4: 6.2-fold (0.79 log units) below, and the stated range ends below it.
By their numbers in this assay, from the lowest: compounds 1 and 3 (each within the scatter of the next); then compounds 2 and 4 (each within the scatter of the next).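

Among these compounds, this is the first single-change pair in the set, and it shows that the position on the carbonyl carbon, whose other neighbour is the double-bonded ring carbon, is sensitive to substitution. In this assay, methylamino in place of methoxy gives a 12-fold higher number from compound 3 to compound 4 (1.09 log units; beyond the scatter), so inhibition is clearly weaker with the methylcarbamoyl group than with the methoxycarbonyl group. The swap keeps the count of heavy atoms and adds no ring or net charge, and nothing measured here accounts for the step.

As far as these compounds go, what a dimethylamino group or a plain amine on this carbonyl carbon would give remains open, so the step cannot yet be assigned to methylamino alone or to amides in general. From the compounds shown here alone, whether an ethoxy group would stay level with methoxy is also open.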